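Chain extension at the alkoxy group of compound 3

The source may report more compounds than this note shows. Statements on the series, on what has been measured and on what is new or still open speak of the compounds shown alone.

Compound 1 `CC(C(=O)NCc1ccc(C(C)(C)C)cc1N1CCCCC1)c1ccc(NS(C)(=O)=O)c(F)c1`: 1.9 nM
Compound 2 `CC1CCN(c2cc(C(C)(C)C)ccc2CNC(=O)C(C)c2ccc(NS(C)(=O)=O)c(F)c2)CC1`: 0.7 nM
Compound 3 `CCCOc1cc(C(C)(C)C)ccc1CNC(=O)C(C)c1ccc(NS(C)(=O)=O)c(F)c1`: 4.4 nM

In an assay on cells for antagonist activity at transient receptor potential cation channel subfamily V member 1 (Homo sapiens), read by FLIPR and calcium flux, with a stated time of 6 min (on this read-out lower numbers stand for stronger inhibition and higher numbers for weaker inhibition), compound 3 stands highest of the three measured numbers, by a 2.3-fold higher number from compound 1 to compound 3 (0.36 log units; beyond the scatter) and a 6.3-fold higher number from compound 2 to compound 3 (0.80 log units; beyond the scatter). Compound 4 `CCCCOc1cc(C(C)(C)C)ccc1CNC(=O)C(C)c1ccc(NS(C)(=O)=O)c(F)c1` differs from it by methyl in place of hydrogen on a saturated chain carbon, three bonds along the chain from an oxygen on an aromatic ring. For the measured compounds named here, only one measured step bears on such an added methyl: a 2.7-fold lower number from compound 1 to compound 2 (0.43 log units; beyond the scatter), where the methyl entered a saturated ring carbon rather than a chain. Going by the values given here, that single step points toward a modestly lower number, but no step tests a chain itself; compound 3 shows lower numbers with the ring groups of compounds 1 and 2. Compound 4 is therefore expected at 3.5 nM (range 1.2 nM to 10 nM), an estimated step of a 1.3-fold lower number from compound 3 to compound 4 (0.10 log units; within the scatter).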

Compound 4, inhibition constant: 1.4 nM
Beside the measured number, compound 4's estimate is 2.5-fold (0.40 log units) above it, within the range that was stated.
By their numbers in this assay, from the lowest: compounds 2, 4 and 1 (each within the scatter of the next, the first and the last beyond it); then compound 3.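

Going from propoxy to butoxy gives a 3.1-fold lower number from compound 3 to compound 4 (0.50 log units; beyond the scatter) in this assay, the only step shown that tests a saturated chain itself, and it lies beyond the scatter. With butoxy at this position, the open chain no longer trails the ring groups: a 2.0-fold higher number from compound 2 to compound 4 (0.30 log units; within the scatter) and a 1.4-fold lower number from compound 1 to compound 4 (0.13 log units; within the scatter) are both within the scatter. Nothing shown accounts for the gain from the added methyl.

As far as these compounds go, whether a longer chain such as pentoxy would continue this trend remains open. So does whether a branched chain or an amine at the chain end would be tolerated here.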